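The source may hold more compounds than are shown below. What is called first, only, known or untested is meant among the compounds shown, and "the series" means these compounds.

Measured so far in an assay on HEK293 cells for negative allosteric modulation of metabotropic glutamate receptor 5 (Homo sapiens), read by FLIPR; a higher number here means a weaker inhibitor, a lower number a stronger inhibitor:

Compound 1, `O=C(c1ccccc1F)N1CC[C@H]1c1nc(-c2cccc(F)c2)no1`: 920 nM
Compound 2, `O=C(c1cccc(F)c1)N1CC(c2nc(-c3cccc(Cl)c3)no2)C1`: 780 nM

Compound 2 has the lower of the two numbers, but its gap to compound 1 lies within the scatter, so the two values show no real separation. For the measured compounds named here, no step between measured compounds that differ in one place is available.

Compound 3, `CC1CCN(C(=O)N2CC(c3nc(-c4cccc(Cl)c4)no3)C2)CC1`, differs from compound 2 in one place: 4-methylpiperidin-1-yl in place of 3-fluorophenyl on a carbonyl carbon. The amide carbonyl is kept, so the change replaces an aromatic ring with a saturated nitrogen-containing ring on the same carbon. Nothing measured here tests such a replacement, so the expectation rests only on the two values above and on the change itself. A moderate shift toward a higher number, beyond the scatter, is expected for compound 3, as a 2.6-fold higher number from compound 2 to compound 3 (0.41 log units; beyond the scatter). Compound 3 is estimated at 2000 nM, with a range from 600 nM to 8000 nM.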

Compound 3, half-maximal inhibitory concentration: > 10000 nM
Compound 3: no number, only a limit; the forecaster's own chance of this, stated with the estimate: 15%; middle value at least 5.0-fold (0.69 log units) away from the limit.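

In this assay compound 3 gives > 10000 nM, which is a limit of the assay and not a number. For the compounds shown here, the change of 3-fluorophenyl to 4-methylpiperidin-1-yl on a carbonyl carbon gives an at least 12-fold higher number from compound 2 to compound 3 (1.10 log units; beyond the scatter), the first evidence that this place is sensitive to the group it carries and does not accept any six-membered ring. The full size of the step cannot be read, and the result sits at the assay's ceiling: the limit of > 10000 nM in this assay, at which 1 of the 3 values shown sits.

The single change removes the aromatic ring, places a ring nitrogen on the carbonyl carbon and adds a methyl group, and the compounds shown do not separate these features. Cyclohexyl or unsubstituted piperidin-1-yl on the same carbon would bear on which of them matters, and so would an unsubstituted phenyl.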